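Series notes: benzoyl in place of nitro

The source may hold more compounds than are shown below. What is called first, only, known or untested is meant among the compounds shown, and "the series" means these compounds.

Of the compounds shown here, two have been measured so far in an ADME assay on PC-3 cells (Homo sapiens) for cytotoxicity, read by WST assay, tested at 100 uM; on this read-out lower numbers stand for less inhibition and higher numbers for more inhibition at the one concentration tested (going by the name of the read-out). Compound 1 `CCc1cccc(NC(=O)C2CCCN(C(=O)c3cc(C(F)(F)F)cc(C(F)(F)F)c3)C2)c1` gives 0% in this assay. Compound 2 `O=C(Nc1cccc([N+](=O)[O-])c1)C1CCCN(C(=O)c2cc(C(F)(F)F)cc(C(F)(F)F)c2)C1` gives 9% in this assay. For the measured compounds named here, the one recorded step between them, a number 9 percentage points higher from compound 1 to compound 2 (within the scatter), is within the scatter, so the two values are not distinguished. Going by the values given here, compound 2 thus stands among two numbers that sit within the scatter of each other, with compound 1 as its only neighbour.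

Compound 3 `O=C(c1ccccc1)c1cccc(NC(=O)C2CCCN(C(=O)c3cc(C(F)(F)F)cc(C(F)(F)F)c3)C2)c1` is not yet measured. It differs from compound 2 in one place: benzoyl in place of nitro on an aromatic carbon. Among the compounds with values here, no measured step covers this exchange; the only step known, from compound 1 to compound 2, also replaces a group on an aromatic carbon and stays within the scatter. On that basis no step beyond the scatter is expected in this assay, and the step estimated is a number 3 percentage points lower from compound 2 to compound 3 (within the scatter). Compound 3 is estimated at 6% in this assay, with an expected range from -5% to 22%.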

Compound 3, a percentage reported as inhibition, at one concentration (the size of the read-out at that concentration, not a potency): 0%
Beside the measured number, compound 3's estimate is 6 percentage points above it; measured number inside the range.
By their numbers in this assay, from the lowest: compounds 1, 3 and 2 (each within the scatter of the next).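

In this assay the aromatic carbon meta to a large group now carries a third kind of group: benzoyl, with its six-membered aromatic ring of carbon only and 8 heavy atoms, in place of nitro with 3 heavy atoms, gives a number 9 percentage points lower from compound 2 to compound 3 (within the scatter) and benzoyl in place of ethyl gives no change at the digits printed from compound 1 to compound 3 (within the scatter). The earlier pair compared only ethyl and nitro, neither of which brings a ring; this result extends the picture to a much larger group, and ethyl, nitro and benzoyl are still not distinguished at this position by this read-out. No measured information is available here to explain why these three compounds are not separated.

Open, as far as these compounds go, is whether any group on this aromatic carbon gives a step beyond the scatter in this assay, for instance a primary amine, a carboxylic acid or a longer chain such as n-hexyl. Also open, from the compounds shown here alone, is whether the same holds once the benzoyl part carrying the two trifluoromethyl groups, shared by all three compounds, is replaced.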